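A Fused Bicycle in Place of the Carboxyphenyl Arm

The compounds below may be only part of what the source reports. "The series", "measured", "known", "first", "only" and "open" are said of these compounds alone.

In a functional assay on MCF7 cells (Homo sapiens) for inhibition, read by MTT assay, with a stated time of 72 h, tested at 10 uM (on this read-out lower numbers stand for less inhibition and higher numbers for more inhibition at the one concentration tested (going by the name of the read-out)), compound 1 `CCOC(=O)C1=C(Nc2ccccc2)S/C(=C\c2ccc(C(=O)O)cc2)C1=O` gives < 10%, which is a limit of the assay and not a number. Compound 2 `CCOC(=O)C1=C(Nc2ccc(OC)cc2)S/C(=C\c2ccc[nH]2)C1=O` likewise returns only a limit, < 10%. Compound 3 `CCOC(=O)C1=C(Nc2cccc(C(F)(F)F)c2)S/C(=C\c2ccc[nH]2)C1=O` gives 22.9% in this assay. Compound 1 thus stands at the limit of < 10% in this assay, at which 2 of the 3 values shown sit, with a single measured value among the compounds shown lying higher. Compound 4 `CCOC(=O)C1=C(Nc2ccccc2)S/C(=C\c2cc3ccncc3[nH]2)C1=O` has not yet been measured; it differs from compound 1 by a group of 9 heavy atoms (7 carbon, 2 nitrogen; one five-membered aromatic ring with 1 hetero atom, one six-membered aromatic ring with 1 hetero atom) in place of a group of 9 heavy atoms (7 carbon, 2 oxygen; one six-membered aromatic ring of carbon only), on a double-bonded chain carbon bound to a double-bonded ring carbon. For the measured compounds named here, no pair of measured compounds differs in one place only, so no measured step guides this change. The step of a number at least 5 percentage points higher from compound 1 to compound 4 (that floor lies within the scatter) is expected to be small, if present at all, and to stay within the scatter. Compound 4 is estimated to give 15%, within 5% to 35%.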

Compound 4, a percentage reported as inhibition, at one concentration (the size of the read-out at that concentration, not a potency): 18.2%
Compound 4: the middle estimate sits 3.2 percentage points below what was measured, within the range that was stated.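

In this assay, putting the fused bicycle in place of the 4-carboxyphenyl group, on a double-bonded chain carbon bound to a double-bonded ring carbon, gives a number at least 8.2 percentage points higher from compound 1 to compound 4 (that floor lies within the scatter). This position therefore accepts a group with a five-membered and a six-membered aromatic ring and no carboxylic acid, and compound 4 still gives a readable 18.2%. The step is only a floor, since compound 1 gives a limit: the limit of < 10% in this assay, at which 2 of the 4 values shown sit.

The compounds shown leave open how large the true step is and whether any rise follows from losing the carboxylic acid or from gaining the bicycle. A simple 4-aminophenyl group at this place could help separate the two.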